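Dropping the Fluoro Group from Compound 2

A few compounds are considered here, and "the series" means these few. Any claim that something is new, unique, unknown or untested is made for them only; others in the source may bear on it.

In a functional assay on OVCAR-4 cells (Homo sapiens) for inhibition (a lower number here means a stronger inhibitor of growth, a higher number a weaker inhibitor of growth), compound 2 `Cc1cc(-c2nc3ccc(F)cc3s2)ccc1N` gives 10 nM, the lowest of the three numbers. Compound 1 `Nc1ccc(-c2nc3ccc(F)cc3s2)cc1Cl` gives 20 nM. That step is a 2.0-fold lower number from compound 1 to compound 2 (0.30 log units; within the scatter). Compound 3 `Nc1ccc(-c2nc3cc(F)ccc3s2)cc1Br` gives 24000 nM, far above both, but it differs from compound 1 in two places at once, so its number alone cannot be tied to a single change. Compound 4 `Cc1cc(-c2nc3ccccc3s2)ccc1N` has not yet been tested; it differs from compound 2 by hydrogen in place of fluoro on an aromatic carbon. For the measured compounds named here, no measured pair shows this change, and the only measured step concerns a different group at a different aromatic carbon, so there is little to lean on. A step of a 1.5-fold higher number from compound 2 to compound 4 (0.18 log units; within the scatter) is expected, no larger than the usual scatter. The estimate for compound 4 is 15 nM, between 5 nM and 60 nM.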

Compound 4, concentration for 50% growth inhibition: 1100 nM
Compound 4: middle estimate off by 73-fold (1.87 log units), on the low side; measured number outside the range, above it.
By their numbers in this assay, from the lowest: compounds 2 and 1 (each within the scatter of the next); then compound 4; then compound 3.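

Fluoro on this aromatic carbon turns out to matter a great deal: in this assay, hydrogen in its place gives a 110-fold higher number from compound 2 to compound 4 (2.04 log units; beyond the scatter). For the compounds shown here, the earlier measured step, chloro to methyl at another aromatic carbon, stayed within the scatter, so this is the first single change here that clearly moves the number. Nothing available explains the size of this step.

Going by these compounds, it remains open whether another group on this carbon, such as methoxy or a nitrile, would keep the number low. On these data alone, it is also open whether removing fluoro costs as much when chloro replaces the methyl.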